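From benzamido to 4-carboxyphenyl: a small step expected

The compounds below may be only part of what the source reports. "The series", "measured", "known", "first", "only" and "open" are said of these compounds alone.

- compound 1 `O=C1Nc2ccc(S(=O)(=O)N3CCOCC3)cc2/C1=N/c1ccc(Br)cc1`: 15300 nM
- compound 2 `Cc1ccc(/N=C2\C(=O)Nc3ccc(S(=O)(=O)N4CCOCC4)cc32)cc1`: 18900 nM
- compound 3 `O=C1Nc2ccc(S(=O)(=O)N3CCOCC3)cc2/C1=N/NC(=O)c1ccccc1`: 28900 nM

All three compounds were tested in a functional assay on HCT-116 cells (Homo sapiens) for cytotoxicity, read by sulforhodamine B assay, with a stated time of 24 h; on this read-out higher numbers stand for weaker inhibition and lower numbers for stronger inhibition. There, compound 3 gives 28900 nM, and its distance to the other two is small: a 1.9-fold higher number from compound 1 to compound 3 (0.28 log units; within the scatter), and a 1.5-fold higher number from compound 2 to compound 3 (0.18 log units; within the scatter). On these numbers, compound 3 cannot be told apart from compound 1 or compound 2.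

Compound 4 `O=C1Nc2ccc(S(=O)(=O)N3CCOCC3)cc2/C1=N/c1ccc(C(=O)O)cc1` has not yet been measured. It keeps the shared core and changes one group: 4-carboxyphenyl in place of benzamido on a double-bonded nitrogen. The entering group is a substituted phenyl, like the groups in compound 1 and compound 2, and moving between such groups and benzamido has so far changed little. Exchanging bromo for methyl also mattered little: a 1.2-fold higher number from compound 1 to compound 2 (0.09 log units; within the scatter). Among the measured compounds shown here, no measured compound carries 4-carboxyphenyl, however, so this group itself remains untested.

No step beyond the scatter is therefore expected in this assay, and the expected change is a 1.4-fold lower number from compound 3 to compound 4 (0.16 log units; within the scatter). For compound 4 the estimated value is 20000 nM, with an expected range from 9000 nM to 45000 nM.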

Compound 4, half-maximal inhibitory concentration: 23600 nM
Estimate against measurement, compound 4: 1.2-fold (0.07 log units) below; low and high end bracket the measured number.
By their numbers in this assay, from the lowest: compounds 1, 2, 4 and 3 (each within the scatter of the next).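

Carrying a carboxy group on the phenyl ring does not separate this position from what came before: in this assay, the exchange of benzamido for 4-carboxyphenyl on the double-bonded nitrogen gives a 1.2-fold lower number from compound 3 to compound 4 (0.09 log units; within the scatter) and so stays small. Carboxy on the aromatic carbon also matches methyl, with a 1.2-fold higher number from compound 2 to compound 4 (0.10 log units; within the scatter), and bromo, with a 1.5-fold higher number from compound 1 to compound 4 (0.19 log units; within the scatter), so all four compounds now cannot be told apart in this assay. Nothing measured here bears on why these exchanges change so little.

On these data alone, whether any group at this position can move the number beyond the scatter stays open, for example an amine on the phenyl ring or a longer chain ending in a carboxylic acid. All four compounds keep the shared core, so the effect of a change there is open too.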